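A few compounds are considered here, and "the series" means these few. Any claim that something is new, unique, unknown or untested is made for them only; others in the source may bear on it.

Working notes on the series.

Of the compounds shown here, two have been measured in a functional assay on CCRF-CEM cells (Homo sapiens) for antiproliferative activity, read by MTT assay, with a stated time of 48 h, tested at 12.5 uM (a lower number here means a stronger effect, a higher number a weaker effect of the compound at the concentration tested), so far. Compound 1 `COc1cccc(C(O)CCn2nc3c(Br)c(Br)c(Br)c(Br)c3n2)c1` carries a 3-methoxyphenyl on a saturated chain carbon bound to an oxygen on a saturated carbon and a saturated chain carbon; in this assay compound 1 gives 96%. Compound 2 `CC(O)CCn1nc2c(Br)c(Br)c(Br)c(Br)c2n1` has methyl at that place, and in this assay compound 2 gives 94%. Going by the values given here, the only step recorded so far is a number 2 percentage points lower from compound 1 to compound 2 (within the scatter). On the numbers shown, compound 2 therefore stands alongside compound 1, the two results being indistinguishable, and both describe a weak effect at the concentration tested.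

Compound 3 `OC(CCn1nc2c(Br)c(Br)c(Br)c(Br)c2n1)c1ccc(Cl)cc1` is not yet measured. It differs from compound 2 as follows: 4-chlorophenyl in place of methyl on a saturated chain carbon bound to an oxygen on a saturated carbon and a saturated chain carbon. The step that bears on this is a number 2 percentage points lower from compound 1 to compound 2 (within the scatter), since it also exchanged an aryl group against methyl at the same place and moved the result by nothing beyond the scatter. No step beyond the scatter is therefore expected in this assay for compound 3 in either direction. Compound 3 is estimated to give 93%, in a range of 80% to 104%, which corresponds to an expected step of a number 1 percentage points lower from compound 2 to compound 3 (within the scatter).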

Compound 3, a percentage reported as activity, at one concentration (the size of the read-out at that concentration, not a potency): 93%
Compound 3: the middle estimate sits on the measured number at the digits printed, within the range that was stated.
By their numbers in this assay, from the lowest: compounds 3, 2 and 1 (each within the scatter of the next).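

In this assay, 4-chlorophenyl in place of methyl on a saturated chain carbon bound to an oxygen on a saturated carbon and a saturated chain carbon gives a step within the scatter (a number 1 percentage points lower from compound 2 to compound 3 (within the scatter)), and 4-chlorophenyl in place of 3-methoxyphenyl at the same place does likewise (a number 3 percentage points lower from compound 1 to compound 3 (within the scatter)). Beyond the earlier pair, this shows that a second aryl group, now carrying chlorine instead of methoxy, also cannot be told apart from methyl, so a change from one heavy atom to seven heavy atoms with a six-membered aromatic ring leaves no readable difference among compounds 1, 2 and 3 at the concentration tested. No measurement shown bears on this result.

As far as these compounds go, how an amine, a carboxylic acid or a longer chain at this place would read in this assay stays open. Also open, from the compounds shown here alone, is whether any change to the shared core itself, rather than to this place, would give a step beyond the scatter.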